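The source may report more compounds than this note shows. Statements on the series, on what has been measured and on what is new or still open speak of the compounds shown alone.

Working notes on the series. Compound 1 `Nc1ncnc2c1cnn2-c1ccc(C(F)(F)F)cc1` carries the shared core with a trifluoromethyl group on the attached benzene ring. In a functional assay on SF-268 cells (Homo sapiens) for inhibition, with a stated time of 48 h (on this read-out higher numbers stand for weaker inhibition of growth and lower numbers for stronger inhibition of growth), compound 1 stands at "not determined" (no result reported), so no number of its own is available, and it can only be placed against the two neighbours that were read. Compound 2 `N#Cc1cnn(-c2ccc(C(F)(F)F)cc2)c1N` is a smaller nitrile-bearing relative. In this assay compound 2 reaches only the limit > 150000 nM, which is a bound of the measurement and not a value. Compound 3 `CC(=O)OC[C@H]1O[C@@H](Nc2ncnc3c2cnn3-c2ccc(C(=O)O)cc2)[C@H](OC(C)=O)[C@@H](OC(C)=O)[C@@H]1OC(C)=O` is a sugar-bearing relative with a carboxylic acid on the benzene ring. In this assay compound 3 likewise stops at the limit > 150000 nM, again a bound rather than a number. Thus the limit of > 150000 nM in this assay, at which 2 of the 3 values shown sit, holds for both measured relatives.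

Compound 4 `COc1ccc(-n2ncc3c(N)ncnc32)cc1` is the next case, differing from compound 1 by methoxy in place of trifluoromethyl on an aromatic carbon. Among the compounds with values here, no measured pair bracketing this change exists, so no step size can be read; the expectation for this assay is no meaningful growth inhibition beyond the scatter. Compound 4 is estimated at 120000 nM, within 30000 nM to 300000 nM.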

Compound 4, concentration for 50% growth inhibition: > 150000 nM
Compound 4 gave a limit, no number; the forecaster's own chance of this, stated with the estimate: 65%; middle value at least 1.2-fold (0.09 log units) away from the limit.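

In this assay compound 4 stops at > 150000 nM, a limit and not a number, so no step can be read between compound 1 and compound 4. The compounds shown leave open whether any substituent on the benzene ring changes growth inhibition, because the readings end at one bound: the limit of > 150000 nM in this assay, at which 3 of the 4 values shown sit.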